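The compounds below may be only part of what the source reports. "The series", "measured", "known", "first", "only" and "open" are said of these compounds alone.

In a functional assay on HCT-116 cells (Homo sapiens) for inhibition, read by sulforhodamine B assay, with a stated time of 48 h (on this read-out higher numbers stand for weaker inhibition of growth and lower numbers for stronger inhibition of growth), compound 2 `CN1CCN(CCCOc2cccc3nc(Nc4ccc(Cl)c(F)c4)ccc23)CC1` gives 1560 nM and compound 1 `CN1CCN(CCCOc2cccc3nc(Nc4ccc(Cl)c(C(F)(F)F)c4)ccc23)CC1` gives 1500 nM, which places the two within the scatter of each other, while compound 3 `CN1CCN(CCCOc2cccc3nc(Nc4ccc(F)c(F)c4)ccc23)CC1` gives 3800 nM. Compound 4 `CN1CCN(CCCOc2cccc3nc(Nc4cccc(Cl)c4)ccc23)CC1` differs from compound 2 by one change, 3-chlorophenyl in place of 4-chloro-3-fluorophenyl on a nitrogen on an aromatic ring. Going by the values given here, no measured step makes this exact change, so two related steps serve as a guide. One is a 1.0-fold higher number from compound 1 to compound 2 (0.02 log units; within the scatter), and the other is the modest 2.4-fold higher number from compound 2 to compound 3 (0.39 log units; beyond the scatter). A small shift is therefore expected, given as a 1.4-fold higher number from compound 2 to compound 4 (0.15 log units; within the scatter), which would stay within the scatter. The estimated value for compound 4 is 2200 nM, with a range of 1100 nM to 4800 nM.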

Compound 4, concentration for 50% growth inhibition: 1550 nM
Beside the measured number, compound 4's estimate is 1.4-fold (0.15 log units) above it; measured number inside the range.
By their numbers in this assay, from the lowest: compounds 1, 4 and 2 (each within the scatter of the next); then compound 3.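

In this assay, 3-chlorophenyl on this nitrogen performs like the larger groups with a second substituent, whether 4-chloro-3-fluorophenyl (a 1.0-fold lower number from compound 2 to compound 4 (0.00 log units; within the scatter)) or 4-chloro-3-(trifluoromethyl)phenyl (a 1.0-fold higher number from compound 1 to compound 4 (0.01 log units; within the scatter)). Among these four compounds, the three with a chlorine on this ring sit together, while 3-chlorophenyl in place of 3,4-difluorophenyl, the one group without chlorine, gives a modest step (a 2.5-fold lower number from compound 3 to compound 4 (0.39 log units; beyond the scatter)). Nothing available explains why these groups behave this way. From the compounds shown here alone, whether an unsubstituted phenyl or a 3-methoxyphenyl on this nitrogen would stay at this level remains open.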